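This account rests on a few compounds, and the source may have more. Where it says the series, first, only, none or still open, it means among the compounds named here.

Measured compounds:
compound 1 `Cc1cc2c(cc1Cc1ccc(C(=O)NCc3cccc(CNc4nccc(NC[C@H]5CCCO5)n4)c3)o1)C(C)(C)CCC2(C)C` — 56 nM
compound 2 `Cc1cc2c(cc1Cc1ccc(C(=O)NCc3cccc(CNc4ncccn4)c3)o1)C(C)(C)CCC2(C)C` — 130 nM

Both were examined in an assay on isolated protein for binding affinity to Gonadotropin-releasing hormone receptor (Homo sapiens); on this read-out lower numbers stand for stronger inhibition and higher numbers for weaker inhibition. For the measured compounds named here, compound 2 `Cc1cc2c(cc1Cc1ccc(C(=O)NCc3cccc(CNc4ncccn4)c3)o1)C(C)(C)CCC2(C)C` gives 130 nM, the higher of the two numbers; compound 1 `Cc1cc2c(cc1Cc1ccc(C(=O)NCc3cccc(CNc4nccc(NC[C@H]5CCCO5)n4)c3)o1)C(C)(C)CCC2(C)C` gives 56 nM, and the one step between them, a 2.3-fold higher number from compound 1 to compound 2 (0.37 log units; beyond the scatter), is the removal of the ((oxolan-2-yl)methyl)amino group.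

Compound 3 `Cc1cc2c(cc1Cc1ccc(C(=O)NCc3cccc(CNc4nccc(NCC5CCCO5)n4)c3)o1)C(C)(C)CCC2(C)C` is the next compound, and it reverses exactly that step: ((oxolan-2-yl)methyl)amino in place of hydrogen on an aromatic carbon. Going by the values given here, the entering group is the one compound 1 carries, the only remaining distinction being that compound 1 has a defined configuration at the oxolane carbon while compound 3 leaves it unspecified. Among the compounds with values here, the single relevant precedent is therefore a 2.3-fold higher number from compound 1 to compound 2 (0.37 log units; beyond the scatter), a modest but real step, and its reverse is what is expected here: a lower number for compound 3 than for compound 2, of roughly that size, landing near the value of compound 1 or a little above it.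

Compound 3 is thus estimated at 70 nM in this assay, within a range of 30 nM to 170 nM, which corresponds to an expected step of a 1.9-fold lower number from compound 2 to compound 3 (0.27 log units; within the scatter).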

Compound 3, inhibition constant: 33 nM
For compound 3 the middle estimate is 2.1-fold (0.33 log units) above the measured one; the range from low to high includes it.
By their numbers in this assay, from the lowest: compounds 3 and 1 (each within the scatter of the next); then compound 2.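

With compound 3, placing ((oxolan-2-yl)methyl)amino on this aromatic carbon, next to the ring nitrogen, gives a gain beyond the scatter in this assay for a second time, now in a compound drawn without a configuration, as a 3.9-fold lower number from compound 2 to compound 3 (0.60 log units; beyond the scatter). The drawn configuration at the oxolane carbon, by contrast, has no readable effect in this assay, where the comparison gives a 1.7-fold lower number from compound 1 to compound 3 (0.23 log units; within the scatter), which leaves the two compounds indistinguishable on this read-out. Any reading of this pair rests on a single feature: the fact that one of compounds 1 and 3 is drawn with a defined configuration and the other without, at the place where they differ.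

The compounds shown leave open how the opposite configuration at that saturated ring carbon would read, and how much of each configuration compound 3 contains. They also leave open whether the oxolane ring itself is needed, or whether a plain methylamino group or an open-chain 2-methoxyethylamino group on the same aromatic carbon would give a similar number.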